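From compound 2 to compound 3

This account rests on a few compounds, and the source may have more. Where it says the series, first, only, none or still open, it means among the compounds named here.

compound 1 `CC(C)=CCCC1(C)C=Cc2c(ccc(C(=O)/C=C/c3ccc(O)c(C=O)c3)c2O)O1` gives 9900 nM as measured
compound 2 `CC(C)=CCCC1(C)C=Cc2ccc(O)c(C(=O)/C=C/c3ccc(O)c(C=O)c3)c2O1` gives 31700 nM as measured

Going by the values given here, both values come from an ADME assay on Vero cells (Chlorocebus sabaeus) for cytotoxicity, read by MTT assay, with a stated time of 72 h (on this read-out lower numbers stand for higher toxicity in this test and higher numbers for lower toxicity in this test), and no other compound has yet been measured there. Compound 2 stands higher of the two with 31700 nM while compound 1 gives 9900 nM and this gap lies beyond the scatter.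

The next compound is compound 3 `CC(C)=CCCC1(C)C=Cc2ccc(O)c(C(=O)/C=C/c3cc(C=O)ccc3O)c2O1` which has the same atoms as compound 2, joined differently. The change is 5-formyl-2-hydroxyphenyl in place of 3-formyl-4-hydroxyphenyl on a double-bonded chain carbon bound to a double-bonded chain carbon and the rest of the molecule stays as it is in compound 2.

Among the compounds with values here, no measured pair shows such a swap, so the data offer no direct guide to its size. Within the data shown here, the expectation therefore starts from compound 2 at 31700 nM and leans slightly towards lower numbers, since the only other value is that of compound 1 at 9900 nM on that side. The expected change is a 1.3-fold lower number from compound 2 to compound 3 (0.12 log units; within the scatter) and it is not expected to go beyond the scatter in this assay at all. The estimate for compound 3 is 24000 nM with an expected range from 9000 nM to 60000 nM as the likely span.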

Compound 3, half-maximal cytotoxic concentration: 103000 nM
For compound 3 the middle estimate is 4.3-fold (0.63 log units) below the measured one; the whole stated range lies below it.
By their numbers in this assay, from the lowest: compound 1; then compound 2; then compound 3.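

Going by these compounds alone, this is the first pair in the set that differs in one place, and it shows that the aryl group on the double-bonded chain carbon bound to a double-bonded chain carbon is not indifferent to how its substituents are arranged: in this assay, 5-formyl-2-hydroxyphenyl in place of 3-formyl-4-hydroxyphenyl gives a 3.2-fold higher number from compound 2 to compound 3 (0.51 log units; beyond the scatter), which on this read-out points to lower toxicity in this test. The two groups match in heavy atoms, hydrogen-bond donors, hydrogen-bond acceptors and charge, so those counts cannot tell them apart, yet the swap of arrangement alone carries the number beyond the scatter. Nothing available explains why the rearranged group shifts the value, and this single step remains an observation without a measured cause.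

The compounds shown leave open whether the same swap would move the number in the same direction on the core of compound 1, because one pair cannot establish a trend. They also leave open what would happen at this place if the formyl group gave way to a carboxylic acid or the hydroxy group to a methoxy group.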